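This account rests on a few compounds, and the source may have more. Where it says the series, first, only, none or still open, it means among the compounds named here.

Compound 1 `CN(C)CCn1c(N)c(-c2nc3ccccc3n2C)c2nc(C#N)c(C#N)nc21` and compound 2 `CCN(CC)CCn1c(N)c(-c2nc3ccccc3n2C)c2nc(C#N)c(C#N)nc21` share a core and differ only where (diethylamino in place of dimethylamino on a saturated chain carbon, two bonds along the chain from an aromatic nitrogen). In a functional assay on HeLa cells (Homo sapiens) for antiproliferative activity, read by MTT assay, with a stated time of 48 h (on this read-out lower numbers stand for stronger inhibition and higher numbers for weaker inhibition), compound 1 gives only a limit of the assay, > 50000 nM. In this assay compound 2 likewise gives only a limit, > 50000 nM. The step that the two limits leave unreadable from compound 1 to compound 2 therefore cannot be read, because both values sit at the limit of > 50000 nM in this assay, at which 3 of the 3 values shown sit. Compound 3 `CN(C)CCn1c(N)c(-c2nc3cc(Cl)ccc3[nH]2)c2nc(C#N)c(C#N)nc21` carries a different core; how its core differs from that of compound 1 is not broken down here. In this assay compound 3 again gives only a limit, > 50000 nM. Compound 4 `CCN(CC)CCn1c(N)c(-c2nc3cc(Cl)ccc3[nH]2)c2nc(C#N)c(C#N)nc21` is not yet measured and differs from compound 3 by diethylamino in place of dimethylamino on a saturated chain carbon, two bonds along the chain from an aromatic nitrogen, the same change as from compound 1 to compound 2. Since that change left compound 2 at the limit, the step that the limit leaves unreadable from compound 3 to compound 4 is expected to be small. Compound 4 is expected to give about 80000 nM in this assay.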

Compound 4, half-maximal inhibitory concentration: > 50000 nM
Compound 4: a limit, no number; the forecaster's own chance of this, stated with the estimate: 85%; the middle value lies beyond the limit too.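

The steps from compound 3 to compound 4 and from compound 2 to compound 4 cannot be read, because each value is a limit, not a number: the limit of > 50000 nM in this assay, at which 4 of the 4 values shown sit.

From the compounds shown here alone, how strongly compound 1, compound 2, compound 3 or compound 4 inhibits these cells, and whether either change alters that, stays open.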